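Swapping a Ring Substituent for a Bromostyryl Arm

The compounds below may be only part of what the source reports. "The series", "measured", "known", "first", "only" and "open" are said of these compounds alone.

Measured compounds:
compound 1 `CN1CCN(Cc2nnc(-c3cc(S(N)(=O)=O)c(SCc4ccccc4)cc3Cl)o2)CC1`: 75000 nM
compound 2 `NS(=O)(=O)c1cc(-c2nnc(CN3CCN(Cc4ccccc4)CC3)o2)c(Cl)cc1SCc1ccccc1`: 26000 nM
compound 3 `NS(=O)(=O)c1cc(-c2nnc(Cn3cc(-c4ccccc4)nn3)o2)c(Cl)cc1SCc1ccccc1`: 75000 nM

Among the compounds with values here, in a functional assay on HCT-116 cells (Homo sapiens) for cytotoxicity, read by MTT assay, with a stated time of 72 h (a higher number here means a weaker inhibitor, a lower number a stronger inhibitor), compound 1 gives 75000 nM, level with compound 3 and together the highest of the three numbers; the only step beyond the scatter is a 2.9-fold lower number from compound 1 to compound 2 (0.46 log units; beyond the scatter). Compound 4 `NS(=O)(=O)c1cc(-c2nnc(/C=C/c3ccc(Br)cc3)o2)c(Cl)cc1SCc1ccccc1` carries one change from compound 1: 2-(4-bromophenyl)ethenyl in place of (4-methylpiperazin-1-yl)methyl on an aromatic carbon. Within the data shown here, no measured step removes this group and adds an unsaturated aromatic arm, so the closest guide is no change at the digits printed from compound 1 to compound 3 (within the scatter), which replaced the same group with an aromatic ring bearing a phenyl and produced no change. A small lowering is plausible given a 2.9-fold lower number from compound 1 to compound 2 (0.46 log units; beyond the scatter), but only within the scatter. Compound 4 is therefore expected to show a 1.5-fold lower number from compound 1 to compound 4 (0.18 log units; within the scatter), with an estimate of 50000 nM (range 15000 nM to 150000 nM).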

Compound 4, half-maximal inhibitory concentration: 15000 nM
For compound 4 the middle estimate is 3.3-fold (0.52 log units) above the measured one, within the range that was stated.
By their numbers in this assay, from the lowest: compounds 4 and 2 (each within the scatter of the next); then compounds 1 and 3 (each within the scatter of the next).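

In this assay the 2-(4-bromophenyl)ethenyl arm gives a 5.0-fold lower number from compound 1 to compound 4 (0.70 log units; beyond the scatter) and also a 5.0-fold lower number from compound 3 to compound 4 (0.70 log units; beyond the scatter) so this position on the five-membered aromatic ring does respond to what it carries, which the earlier swap of its substituent had not shown. The entering arm holds only carbon and bromine, so a nitrogen in this arm is not required for the lower number. Nothing available explains this step. Going by these compounds, whether the bromine or the double bond matters stays open: a 2-phenylethenyl arm without bromine, or a saturated ethyl chain bearing 4-bromophenyl, would separate the two.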